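Styryl replacing hydroxyphenyl on the core of compound 1

The source may hold more compounds than are shown below. What is called first, only, known or untested is meant among the compounds shown, and "the series" means these compounds.

Going by the values given here, compound 1 `C/C(CC(=O)Nc1nnc(-c2ccc(O)cc2)s1)=N\c1ccc([N+](=O)[O-])cn1` gives 3.34 in a physicochemical assay for lipophilicity, measured as octanol-water partition (on this read-out higher numbers stand for higher lipophilicity and lower numbers for lower lipophilicity), and stands lowest of the three numbers measured so far. Compound 2 `C/C(CC(=O)Nc1nnc(-c2ccc(O)cc2)s1)=N\c1ccccn1` gives 3.43 in this assay; the change from compound 1, hydrogen in place of nitro on an aromatic carbon, produced a number 0.09 log units higher from compound 1 to compound 2 (within the scatter). Among the compounds with values here, compound 3 `CC(=O)Oc1ccccc1-c1nnc(NC(=O)C/C(C)=N/c2ccccn2)s1` gives 3.65 in this assay, a number above compound 1 beyond the scatter, but compound 3 differs from the others in more than one place, so no single step is drawn from it.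

Compound 4 `C/C(CC(=O)Nc1nnc(/C=C/c2ccccc2)s1)=N\c1ccc([N+](=O)[O-])cn1` is not yet measured. It differs from compound 1 by 2-phenylethenyl in place of 4-hydroxyphenyl on an aromatic carbon. Within the data shown here, no measured step bears on this change: the only counted step, from compound 1 to compound 2, concerns the nitro group, which compound 4 keeps. The expectation rests on what leaves and what enters: a hydroxyl-bearing ring gives way to a phenylethenyl group with no donor or acceptor, so a step upward is expected, estimated at a number 0.91 log units higher from compound 1 to compound 4 (beyond the scatter). For compound 4 the expected value in this assay is 4.25, within a range from 3.7 to 4.8.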

Compound 4, partition coefficient: 4.13
For compound 4 the middle estimate is 0.12 log units above the measured one; the measured number falls inside the stated range.
By their numbers in this assay, from the lowest: compounds 1, 2 and 3 (each within the scatter of the next, the first and the last beyond it); then compound 4.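

In this assay, going by these compounds alone, the group on the aromatic carbon of the shared core gives a step of a different order from the one at the nitro group: 2-phenylethenyl in place of 4-hydroxyphenyl gives a number 0.79 log units higher from compound 1 to compound 4 (beyond the scatter) and is the first single-place step to pass the scatter, whereas hydrogen in place of nitro gives a number 0.09 log units higher from compound 1 to compound 2 (within the scatter) and does not. This position therefore moves the read-out, and the entering group, with 0 hydrogen-bond donors and 0 hydrogen-bond acceptors, sits at the higher number. No measurement shown gives a reason for the step.

Within the data shown here, the single step changes the hydroxyl and the double bond together, so a plain phenyl or a 4-methoxyphenyl at this position would be needed to separate the two. On these data alone, whether the step holds with hydrogen in place of nitro remains open.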